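This account rests on a few compounds, and the source may have more. Where it says the series, first, only, none or still open, it means among the compounds named here.

Measured so far in a toxicity assay on THP-1 cells (Homo sapiens) for inhibition; a higher number here means that more compound is tolerated, a lower number that less compound is tolerated:
compound 1 `Cn1c(-c2cccc(C#N)c2)cnc1NC(=O)c1ccc(F)cc1`: > 100000 nM, a limit only
compound 2 `Cn1c(-c2cccc(C#N)c2)cnc1NC(=O)c1ncc[nH]1`: > 50000 nM, a limit only
compound 3 `COc1ccc(-c2ccnc(NC(=O)c3ccc(F)cc3)c2)cc1`: > 100000 nM, a limit only

Compound 1 therefore stands only at a limit in this assay, and the two further values are limits as well. The one step among these compounds, a step that the two limits leave unreadable from compound 1 to compound 2, is not readable. Both of its ends sit at limits, the limit of > 100000 nM in this assay, at which 2 of the 3 values shown sit, and (the limit of > 50000 nM in this assay, at which 1 of the 3 values shown sits).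

Compound 4 `Cn1c(-c2ccccc2Cl)cnc1NC(=O)c1ccc(F)cc1` differs from compound 1 by 2-chlorophenyl in place of 3-cyanophenyl on an aromatic carbon. For the measured compounds named here, no measured step bears on this change. Two of the three values sit at the limit of > 100000 nM in this assay, at which 2 of the 3 values shown sit, so compound 4 is expected to sit at the same limit, with no step beyond the scatter in either direction. The step of a number no higher from compound 1 to compound 4 (the limit leaves the size open) is thus expected to stay within the scatter. The estimate for compound 4 is 100000 nM, in the range 50000 nM to 200000 nM.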

Compound 4, half-maximal cytotoxic concentration: > 50000 nM
Compound 4: only a limit was reported (the forecaster's own chance of this, stated with the estimate: 85%); the middle value does not contradict the limit.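

For the compounds shown here, compound 1 and compound 4 both stand only at limits in this assay; no step between them can be read. The compounds shown leave open whether 2-chlorophenyl in place of 3-cyanophenyl shifts the tolerated concentration at all.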